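The compounds below may be only part of what the source reports. "The series", "measured", "known", "first", "only" and "open" are said of these compounds alone.

Compound 2 `O=C(O)Cc1sc(C(c2ccccc2)c2ccccc2)nc1-c1ccc(F)cc1`: 77 nM
Compound 1 `COc1ccc(C(c2ccccn2)c2nc(-c3ccc(Cl)cc3)c(CC(=O)O)s2)cc1`: 310 nM

For the measured compounds named here, in an in vitro functional assay on HEK285-7 cells for antagonist activity at prostaglandin D2 receptor 2 (Homo sapiens), read by BRET and beta-arrestin recruitment (a lower number here means a stronger inhibitor, a higher number a weaker inhibitor), compound 2 gives 77 nM, the lowest of the two numbers measured so far. Going by the values given here, the only other measured compound, compound 1, gives 310 nM, and the gap between the two lies beyond the usual scatter of repeated measurements. Compound 1 differs from compound 2 in several places at once, so no single structural change can be read from that gap.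

Compound 3 `COc1ccc(OC)c(-c2nc(C(c3ccccc3)c3ccccc3)sc2CC(=O)O)c1` has not yet been measured. It differs from compound 2 in one place only: 2,5-dimethoxyphenyl in place of 4-fluorophenyl on an aromatic carbon. Everything else in compound 2 is kept. Among the compounds with values here, no pair of measured compounds that differ in just one place is available, so there is no measured step to lean on, and the effect of this exchange can only be estimated. A moderate change in either direction would not be surprising; the expected step is a 1.9-fold higher number from compound 2 to compound 3 (0.29 log units; within the scatter), a slight weakening. Compound 3 is therefore expected to give about 150 nM in this assay, with a plausible range from 40 nM to 600 nM.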

Compound 3, half-maximal inhibitory concentration: > 100000 nM
Compound 3 was reported as a limit (the forecaster's own chance of this, stated with the estimate: 5%); middle value at least 660-fold (2.82 log units) from the limit.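

For the compounds shown here, exchanging 4-fluorophenyl for 2,5-dimethoxyphenyl on this aromatic carbon, next to the ring nitrogen and next to the ring atom that bears the carboxymethyl group, gives an at least 1200-fold higher number from compound 2 to compound 3 (3.11 log units; beyond the scatter) in this assay, the first step here that can be tied to a single place, and it shows that this one position can decide whether inhibition is measurable at all. On these data alone, the value of compound 3 is a limit of the assay and not a number, so the real size of this step remains unknown: the limit of > 100000 nM in this assay, at which 1 of the 3 values shown sits. Both groups hold one six-membered aromatic ring of carbon only, so the large loss comes with a change in what that ring carries, not with the loss of the ring itself.

The fluorine leaves and two methoxy groups enter in the same step, so the compounds shown cannot tell whether one methoxy group, both of them or the missing fluorine accounts for the loss. A phenyl ring carrying a single methoxy group, or a small methyl group in place of the whole ring, would show how much of this position's sensitivity comes from each.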